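A few compounds are considered here, and "the series" means these few. Any claim that something is new, unique, unknown or untested is made for them only; others in the source may bear on it.

Measured so far in an ADME assay on the whole organism (Mus musculus, strain ICR) for metabolic stability, read by LC-MS, with a stated time of 24 h, at a dose of 10 mg/kg by the oral route; a higher number here means that the compound lasts longer, a lower number that the compound disappears faster:
compound 1 `CCN1CCN(c2cc(Nc3cc(C)nn3C(=O)C(C)(C)C)nc(N[C@H]3CCN(C(=O)c4ccc(Cl)cc4F)C3)n2)CC1` gives 2.2 h
compound 2 `CCN1CCN(c2cc(Nc3cc(C)nn3C(=O)OC(C)(C)C)nc(N[C@H]3CCN(C(=O)c4ccc(Cl)cc4F)C3)n2)CC1` gives 3.3 h

Compound 1 holds the lower of the two half-life numbers, with compound 2 nearest; the difference a 1.5-fold higher number from compound 1 to compound 2 (0.18 log units; within the scatter) does not separate the two compounds.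

Compound 3 `CCOC(=O)n1nc(C)cc1Nc1cc(N2CCN(CC)CC2)nc(N[C@H]2CCN(C(=O)c3ccc(Cl)cc3F)C2)n1` is not yet measured. Relative to compound 1 the change is ethoxy in place of tert-butyl on a carbonyl carbon, so the acyl group on the pyrazole nitrogen becomes a carbamate again, as in compound 2, but with a shorter alkoxy group.

Within the data shown here, only one measured step bears on this change: the swap of tert-butyl for tert-butoxy at the same carbonyl carbon, a 1.5-fold higher number from compound 1 to compound 2 (0.18 log units; within the scatter), which stayed within the scatter. Among the measured compounds shown here, no measured pair speaks to ethoxy against tert-butoxy. The expected step of a 1.2-fold higher number from compound 1 to compound 3 (0.07 log units; within the scatter) is therefore small, in the same direction as compound 2 at most, and not clearly beyond the scatter. Compound 3 is estimated at 2.6 h in this assay, with a range of 1.3 h to 5.2 h.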

Compound 3, half-life: 2.7 h
Compound 3: the middle estimate sits 1.0-fold (0.02 log units) below what was measured; measured number inside the range.
By their numbers in this assay, from the lowest: compounds 1, 3 and 2 (each within the scatter of the next).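

In this assay the ethoxy group gives a second reading at this carbonyl carbon, with a 1.2-fold higher number from compound 1 to compound 3 (0.09 log units; within the scatter) for ethoxy in place of tert-butyl and a 1.2-fold lower number from compound 2 to compound 3 (0.09 log units; within the scatter) for ethyl in place of tert-butyl on the oxygen. Both steps stay within the scatter, so tert-butyl, tert-butoxy and ethoxy are not separated by half-life here, and exchanging tert-butyl for ethyl on the oxygen leaves no readable difference. No measurement at hand offers a reason for these closely spaced half-lives.

Still open, going by these compounds, is whether a group of another kind on this carbonyl carbon, such as a dialkylamine or a benzyloxy group, would give a step beyond the scatter. Also open, on these data alone, is whether a longer chain ending in a carboxylic acid or an amine would do so.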